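This account rests on a few compounds, and the source may have more. Where it says the series, first, only, none or still open, it means among the compounds named here.

Measured compounds:
compound 1 `Nc1ccccc1NC(=O)c1ccc(CSC(=S)N2CCN(Cc3ccccn3)CC2)cc1` — 82.4%
compound 2 `Nc1ccccc1NC(=O)c1ccc(CSC(=S)N2CCN(c3ccccc3)CC2)cc1` — 88.6%
compound 3 `Nc1ccccc1NC(=O)c1ccc(CSC(=S)N2CCN(Cc3ccncc3)CC2)cc1` — 89.5%

In a functional assay on A-375 cells (Homo sapiens) for antiproliferative activity, read by CCK-8 assay, with a stated time of 72 h, tested at 8 uM (on this read-out lower numbers stand for a weaker effect and higher numbers for a stronger effect at the one concentration tested), compound 3 carries the largest of the three numbers, but the gap to compound 2, a number 0.9 percentage points higher from compound 2 to compound 3 (within the scatter), and the gap to compound 1, a number 7.1 percentage points higher from compound 1 to compound 3 (within the scatter), both lie within the scatter, so the three compounds are not separated by this assay.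

Compound 4 `Nc1ccccc1NC(=O)c1ccc(CSC(=S)N2CCN(c3cnccn3)CC2)cc1` differs from compound 3 by pyrazin-2-yl in place of (pyridin-4-yl)methyl on an amine nitrogen in a ring. For the measured compounds named here, two measured steps touch the same place. The step of a number 6.2 percentage points higher from compound 1 to compound 2 (within the scatter) and the step of a number 0.9 percentage points higher from compound 2 to compound 3 (within the scatter) both exchange a ring group on that amine nitrogen, and neither moved the read-out beyond the scatter. On that basis compound 4 is expected to show a step of a number 3.5 percentage points lower from compound 3 to compound 4 (within the scatter), with no change beyond the scatter in either direction. Compound 4 is therefore estimated at 86%, within a range from 72% to 94%.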

Compound 4, a percentage reported as inhibition, at one concentration (the size of the read-out at that concentration, not a potency): 85.8%
Compound 4: middle estimate off by 0.2 percentage points, on the high side; the measured number falls inside the stated range.
By their numbers in this assay, from the lowest: compounds 1, 4, 2 and 3 (each within the scatter of the next).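

Compound 4 puts on this amine nitrogen a six-membered aromatic ring with 2 hetero atoms, which none of the other three compounds carries, and this assay does not separate it from any of them: the read-out gives a number 3.7 percentage points lower from compound 3 to compound 4 (within the scatter) and a number 2.8 percentage points lower from compound 2 to compound 4 (within the scatter) and a number 3.4 percentage points higher from compound 1 to compound 4 (within the scatter) as its three steps. The direct exchange of phenyl for pyrazin-2-yl is the most telling of these, since it changes only the ring atoms of a group on that nitrogen and still leaves the number within the scatter. No measured evidence on the cause of this outcome is available.

Going by these compounds, whether a carboxylic acid, a primary amine or a longer chain at this position would move the read-out beyond the scatter stays open. So does any ordering of these four compounds, since the single concentration tested leaves all of them close together.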